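The compounds below may be only part of what the source reports. "The series", "measured", "known", "first", "only" and "open" are said of these compounds alone.

Measured compounds:
compound 1 `COc1cc2c(cc1OC)C(CC(=O)Nc1cccc(Cl)c1)CC2`, 51.5%
compound 2 `COc1cc2c(cc1OC)C(CC(=O)Nc1ccccc1C)CC2`, 30%
compound 3 `COc1cc2c(cc1OC)C(CC(=O)Nc1cccc(C)c1)CC2`, 54.3%

All three were tested in a functional assay on the whole organism (strain Swiss Albino) for inhibition, with Mus musculus as the target, in the writhing test, with a stated time of 1 h, at a dose of 100 mg/kg by the oral route; on this read-out higher numbers stand for more inhibition at the one dose given (going by the name of the read-out) and lower numbers for less inhibition. Compound 3 holds the highest of the three numbers, but the step of a number 2.8 percentage points higher from compound 1 to compound 3 (within the scatter) is within the scatter, so no order between those two can be claimed. The step of a number 24.3 percentage points higher from compound 2 to compound 3 (beyond the scatter) is beyond the scatter, so compound 2 does sit lower.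

Compound 4 `COc1ccccc1NC(=O)CC1CCc2cc(OC)c(OC)cc21` has not yet been measured. The change from compound 3 is 2-methoxyphenyl in place of 3-methylphenyl on an amide-type nitrogen.

For the measured compounds named here, two measured steps bear on this change: a number 21.5 percentage points lower from compound 1 to compound 2 (beyond the scatter) and a number 24.3 percentage points higher from compound 2 to compound 3 (beyond the scatter). In both, the compound carrying 2-methylphenyl on the amide nitrogen gives the lower number, while 3-chlorophenyl and 3-methylphenyl give numbers within the scatter of each other. Going by the values given here, compound 4 likewise carries a 2-substituted ring, 2-methoxyphenyl, but no measured compound carries a methoxy on that ring, so the size of the effect is uncertain. A modest drop below compound 3 is therefore expected for compound 4, a number 18.3 percentage points lower from compound 3 to compound 4 (beyond the scatter). The estimated value for compound 4 is 36%, with a range from 20% to 52%.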

Compound 4, a percentage reported as inhibition, in the whole organism at one dose (the size of the read-out at that dose, not a potency): 24.5%
For compound 4 the middle estimate is 11.5 percentage points above the measured one, and the stated range covers the measured number.
By their numbers in this assay, from the lowest: compounds 4 and 2 (each within the scatter of the next); then compounds 1 and 3 (each within the scatter of the next).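

In this assay, 2-methoxyphenyl on the amide-type nitrogen gives a clearly lower number than either ring with a group at the 3 position, a number 29.8 percentage points lower from compound 3 to compound 4 (beyond the scatter) and a number 27 percentage points lower from compound 1 to compound 4 (beyond the scatter), so the low result of the 2-methylphenyl ring is no longer a single case. Methoxy and methyl on the 2-substituted ring cannot be told apart, a number 5.5 percentage points lower from compound 2 to compound 4 (within the scatter), and so among these four compounds both 2-substituted rings sit low and both 3-substituted rings sit high, with no compound going against this. No measurement is available that explains this difference.

The compounds shown leave open whether the low numbers follow the place of the group on the ring in general, which a 3-methoxyphenyl ring and a 2-chlorophenyl ring would test directly, as each pairs a known group with the other place. Also open, going by these compounds, is how an unsubstituted phenyl ring, or a ring carrying an amine or a carboxylic acid, would compare with these four at the same dose.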